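Fluoro in place of chloro on an aromatic carbon

A few compounds are considered here, and "the series" means these few. Any claim that something is new, unique, unknown or untested is made for them only; others in the source may bear on it.

Compound 1 (`O=C(NNc1cccc(Cl)c1)c1ccc(NS(=O)(=O)c2cnc(O)nc2O)cc1`) gives 8410 nM in the first measurement
Compound 2 (`O=C(NNC(=O)c1ccccc1Cl)c1ccc(NS(=O)(=O)c2cnc(O)nc2O)cc1`) gives 5220 nM in the second measurement

In a functional assay on OVCAR-3 cells (Homo sapiens) for antiproliferative activity, read by MTT assay, with a stated time of 24 h (on this read-out lower numbers stand for stronger inhibition and higher numbers for weaker inhibition), compound 2 stands within the scatter of compound 1, so no order can be drawn between them. Compound 3 (`O=C(NNC(=O)c1ccccc1F)c1ccc(NS(=O)(=O)c2cnc(O)nc2O)cc1`) carries fluoro in place of chloro on an aromatic carbon, ortho to a large group (fluoro in place of chloro on an aromatic carbon). Among the measured compounds shown here, the only measured step (a 1.6-fold lower number from compound 1 to compound 2 (0.21 log units; within the scatter)) is a different change and does not test this swap. No step beyond the scatter is therefore expected in this assay for compound 3. The expected step (a 1.1-fold higher number from compound 2 to compound 3 (0.02 log units; within the scatter)) is small. Compound 3 is estimated at 5500 nM with an expected range from 2600 nM to 11000 nM in this read-out.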

Compound 3, half-maximal inhibitory concentration: 16000 nM
The estimate for compound 3 lay 2.9-fold (0.46 log units) below the measured number, and the stated range ends below it.
By their numbers in this assay, from the lowest: compounds 2, 1 and 3 (each within the scatter of the next, the first and the last beyond it).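

In this assay, among the compounds shown here, the halogen on this aromatic carbon, ortho to a large group, is not interchangeable: fluoro in place of chloro gives a 3.1-fold higher number from compound 2 to compound 3 (0.49 log units; beyond the scatter), the first step beyond the scatter. By contrast, exchanging the group on the amine nitrogen gives a 1.9-fold higher number from compound 1 to compound 3 (0.28 log units; within the scatter), which separates neither compound from the other. Nothing available here accounts for the halogen step. As far as these compounds go, whether a bromo, methoxy or amino group at this place would stay with compound 2 or with compound 3 remains open.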